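Short-linker dichlorophenyl amide after an inactive propoxyphenyl parent

A few compounds are considered here, and "the series" means these few. Any claim that something is new, unique, unknown or untested is made for them only; others in the source may bear on it.

Compound 1 `CCCOc1ccc(NC(=O)CSc2nnc(Cc3nn(C)c(=O)c4ccccc34)n2C)cc1`: > 30000 nM
Compound 2 `Cn1c(Cc2nn(C)c(=O)c3ccccc23)nnc1SCCCCCCCC(=O)Nc1ccc(Cl)cc1Cl`: 1900 nM
Compound 3 `CC(C)Oc1ccc(NC(=O)CCCCCCCSc2nnc(Cc3nn(C)c(=O)c4ccccc34)n2C)cc1`: 1100 nM

In an assay on isolated protein (Mus musculus) for inhibition of IL15-IL15 receptor (Homo sapiens), read by resazurin assay, with stated times of 30 min and 2.5 days (on this read-out lower numbers stand for stronger inhibition and higher numbers for weaker inhibition), compound 1 gives only a limit, > 30000 nM, and so stands at the weak end of the three values, at the limit of > 30000 nM in this assay, at which 1 of the 3 values shown sits. Compound 4 `Cn1c(Cc2nn(C)c(=O)c3ccccc23)nnc1SCC(=O)Nc1ccc(Cl)cc1Cl` differs from compound 1 by 2,4-dichlorophenyl in place of 4-propoxyphenyl on an amide-type nitrogen. For the measured compounds named here, the only measured change of the same kind is a 1.7-fold lower number from compound 2 to compound 3 (0.24 log units; within the scatter), made on a longer linking chain than the one shared by compound 1 and compound 4, so it bears on the new step only loosely. Since compound 1 is itself a limit, the expected step that the limit leaves unreadable from compound 1 to compound 4 is unlikely to resolve into a measured difference, and compound 4 is expected to come out near 40000 nM, between 8000 nM and 200000 nM, most likely again as a limit.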

Compound 4, half-maximal inhibitory concentration: 17300 nM
Beside the measured number, compound 4's estimate is 2.3-fold (0.36 log units) above it; the range from low to high includes it.
By their numbers in this assay, from the lowest: compounds 3 and 2 (each within the scatter of the next); then compound 4. At a limit, above all of these: compound 1.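

In this assay, 2,4-dichlorophenyl in place of 4-propoxyphenyl on the amide-type nitrogen gives an at least 1.7-fold lower number from compound 1 to compound 4 (0.23 log units; that floor lies within the scatter). Compound 1 is a limit, > 30000 nM, so the full size of this step cannot be read. Compound 4 gives the short chain its first measured value, 17300 nM, while compound 2, with the same 2,4-dichlorophenyl on a longer chain, reads 1900 nM.

Left open is how a chain of intermediate length would read with 2,4-dichlorophenyl. Also open, as far as these compounds go, is whether a carboxylic acid or an amine on that ring would change the short-chain value.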